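The source may hold more compounds than are shown below. What is called first, only, known or untested is meant among the compounds shown, and "the series" means these compounds.

Measured compounds in a functional assay on ACHN cells (Homo sapiens) for inhibition; a higher number here means a weaker inhibitor of growth, a lower number a stronger inhibitor of growth:

- compound 1 `C=C1CCC[C@H]2[C@](C)(CC[C@]3(C)CC[C@H]([C@@H](C)C(=O)O)OO3)[C@@H](C)CC[C@]12C`: 1380 nM
- compound 2 `C=C1CCC[C@H]2[C@](C)(CCC(C)=O)[C@@H](C)CC[C@]12C`: limit only, > 15000 nM

Compound 1 holds the only numerical result so far in this assay, with 1380 nM. For compound 2 the assay reports only a limit and no number, > 15000 nM. Within the data shown here, of the two entries in this assay, one therefore sits at the limit (the limit of > 15000 nM in this assay, at which 1 of the 2 values shown sits), so compound 1 has nothing measured to be ranked against; it stands alone as the one compound with a measured growth inhibition.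

The step under consideration leads to compound 3 `C=C1CCC[C@H]2[C@](C)(CC[C@]3(C)CC[C@@H]([C@@H](C)C(=O)O)OO3)[C@@H](C)CC[C@]12C`. Relative to compound 1 the change is the two compounds have the same atoms and bonds and differ only in configuration as drawn: 1 of 7 stereo elements differ; a stereocentre at a saturated ring carbon is drawn R in compound 1 and S in compound 3. No pair of measured compounds differing in a single place is available, so the size of a step of this kind in this assay cannot be read from the data. The expectation for the step from compound 1 to compound 3 is a 1.8-fold higher number from compound 1 to compound 3 (0.26 log units; within the scatter), a shift that may stay within the scatter or extend somewhat toward weaker inhibition, with the direction uncertain.

Compound 3 is estimated at 2500 nM in this assay, within a range of 700 nM to 9000 nM.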

Compound 3, concentration for 50% growth inhibition: 920 nM
Compound 3: middle estimate off by 2.7-fold (0.43 log units), on the high side; low and high end bracket the measured number.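

Inverting the saturated ring carbon from R in compound 1 to S in compound 3 gives the first readable step in this series: in this assay, the step is a 1.5-fold lower number from compound 1 to compound 3 (0.18 log units; within the scatter). At this stereocentre, therefore, the assay does not separate the two drawn configurations, and both compounds retain a measured growth inhibition rather than a limit. The step can be assigned to configuration alone, with no change of group involved, because of one fact: the fact that compounds 1 and 3 differ only in the configuration as drawn

Compound 2 gives only a limit, > 15000 nM, and so adds no number against which this stereocentre or the carboxylic acid side chain can be judged. The compounds shown leave open how the other stereo elements bear on growth inhibition, and whether a methyl ester or a primary amide in place of the carboxylic acid would keep the result equally indifferent to the configuration at this ring carbon.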